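The source may hold more compounds than are shown below. What is called first, only, known or untested is meant among the compounds shown, and "the series" means these compounds.

Three compounds share one core and differ only in the group attached on a saturated chain carbon bound to an oxygen next to a carbonyl group. In an assay for inhibition of serine/threonine-protein kinase PAK 4 (Homo sapiens), read by FRET and Z'-LYTE, with a stated time of 60 min, tested at 50 uM, in the presence of a further agent that is not named here (on this read-out lower numbers stand for a weaker effect and higher numbers for a stronger effect at the one concentration tested), compound 1 `C[C@@H]1CN(C(=O)c2nc(Nc3cc(C4CC4)[nH]n3)c3cc(Cl)ccc3n2)CCN1C(=O)OCc1ccccc1` gives 96%, and compound 2 `COC(=O)N1CCN(C(=O)c2nc(Nc3cc(C4CC4)[nH]n3)c3cc(Cl)ccc3n2)C[C@H]1C` gives 98.5%; the step of a number 2.5 percentage points higher from compound 1 to compound 2 (within the scatter) lies within the scatter. Compound 3 `C[C@@H]1CN(C(=O)c2nc(Nc3cc(C4CC4)[nH]n3)c3cc(Cl)ccc3n2)CCN1C(=O)OCOC(=O)C(C)(C)C` stands lowest of the three: in this assay compound 3 gives 60.5%, and the steps of a number 35.5 percentage points lower from compound 1 to compound 3 (beyond the scatter) and a number 38 percentage points lower from compound 2 to compound 3 (beyond the scatter) are both large and beyond the scatter. Compound 4 `CCOC(=O)N1CCN(C(=O)c2nc(Nc3cc(C4CC4)[nH]n3)c3cc(Cl)ccc3n2)C[C@H]1C` has not yet been measured. Its change from compound 3 is methyl in place of ((tert-butyl)carbonyl)oxy on a saturated chain carbon bound to an oxygen next to a carbonyl group. The two steps into compound 3 bear directly on this change, since the group that leaves here is the very group whose entry marked a number 38 percentage points lower from compound 2 to compound 3 (beyond the scatter) and a number 35.5 percentage points lower from compound 1 to compound 3 (beyond the scatter). A large step upward in this assay is therefore expected, a number 34.5 percentage points higher from compound 3 to compound 4 (beyond the scatter), bringing the number back toward those of compound 1 and compound 2. Compound 4 is estimated to give 95%, within a range from 84% to 100%.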

Compound 4, a percentage reported as inhibition, at one concentration (the size of the read-out at that concentration, not a potency) in the serine/threonine-protein kinase PAK 4 assay: 93.4%
The estimate for compound 4 lay 1.6 percentage points above the measured number; low and high end bracket the measured number.
By their numbers in the serine/threonine-protein kinase PAK 4 assay, from the lowest: compound 3; then compounds 4, 1 and 2 (each within the scatter of the next).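

Replacing ((tert-butyl)carbonyl)oxy with methyl at this place reverses the loss: in the serine/threonine-protein kinase PAK 4 assay compound 3 gives 60.5% and compound 4 gives 93.4%, which is a number 32.9 percentage points higher from compound 3 to compound 4 (beyond the scatter) and a large step, whereas a number 5.1 percentage points lower from compound 2 to compound 4 (within the scatter) and a number 2.6 percentage points lower from compound 1 to compound 4 (within the scatter) are both small, so methyl joins hydrogen and phenyl and only compound 3 stands apart among these four. Among the compounds shown here, in a physicochemical assay, read by HPLC, in phosphate buffer, with a stated time of 2 h, at pH 7.4 (a lower number here means that less of the compound is left, a higher number that more of the compound is left), compound 3 gives 97.7% and compound 4 gives 97.7%, which is no change at the digits printed from compound 3 to compound 4 (within the scatter), so the large gap in the kinase read-out has no counterpart in the amount of compound left in buffer. Nothing measured here explains why compound 3 stands apart.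

Still open, going by these compounds, is whether an amine, a carboxylic acid or a longer chain such as propyl at this saturated chain carbon would keep the number as high as methyl does. On these data alone, each kinase number also comes from a single concentration, so the potencies of compounds 1, 2 and 4 remain open.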